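Bromo for methyl on the sulfonyl aryl ring

A few compounds are considered here, and "the series" means these few. Any claim that something is new, unique, unknown or untested is made for them only; others in the source may bear on it.

Compound 1 `Cc1ccc(S(=O)(=O)NC(=O)c2cncc(Br)c2)cc1` and compound 2 `O=C(NS(=O)(=O)c1ccc(Br)cc1)c1cncc(Br)c1` share one core; compound 3 `Cc1ccc(S(=O)(=O)NC(=O)c2ccc(C)nc2Cl)cc1` and compound 4 `Cc1ccc(C(=O)NS(=O)(=O)c2ccc(Br)cc2)c(Cl)n1` share another, and the difference between the two cores is not broken down here. In a functional assay on MCF7 cells (Homo sapiens) for antiproliferative activity, read by MTT assay, with a stated time of 48 h (on this read-out lower numbers stand for stronger inhibition and higher numbers for weaker inhibition), compound 1 gives 9370 nM and compound 2 gives 340 nM; the step of a 28-fold lower number from compound 1 to compound 2 (1.44 log units; beyond the scatter) follows from bromo in place of methyl on an aromatic carbon. In this assay compound 3 gives 8520 nM, close to compound 1. Compound 4 carries the same change, (bromo in place of methyl on an aromatic carbon), at the same place. Because the earlier example gave a 28-fold lower number from compound 1 to compound 2 (1.44 log units; beyond the scatter), a step of similar size is expected here, a 21-fold lower number from compound 3 to compound 4 (1.33 log units; beyond the scatter), taken a little smaller since it rests on a single pair. Compound 4 is therefore estimated at 400 nM, between 130 nM and 1300 nM.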

Compound 4, half-maximal inhibitory concentration: 1970 nM
Estimate against measurement, compound 4: 4.9-fold (0.69 log units) below, outside the stated range (above it).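

In this assay, bromo in place of methyl on the sulfonyl aryl ring again gives a lower number on the second core, with a 4.3-fold lower number from compound 3 to compound 4 (0.64 log units; beyond the scatter), so the direction of the step carries over between these two cores. The size does not carry over: the same change on two cores in this assay, a 28-fold lower number (1.44 log units; beyond the scatter) from compound 1 to compound 2 and a 4.3-fold lower number (0.64 log units; beyond the scatter) from compound 3 to compound 4, 6.4-fold (0.80 log units) apart, beyond the scatter of two such steps. These two pairs do not show which difference between the cores goes with the smaller step, and they give no rule for the size of the step on a further core.

Open, on these data alone, is whether a fluoro, a methoxy or an amine in place of the methyl would also give a lower number on either core. Also open, as far as these compounds go, is whether the same direction holds on cores beyond these two.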